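Ester and amide piperazinyl bornyl derivatives: cytotoxicity notes

The compounds below may be only part of what the source reports. "The series", "measured", "known", "first", "only" and "open" are said of these compounds alone.

The series rests on two cores. Compound 1 `CN1CCN(CC(=O)O[C@@H]2C[C@@H]3CC[C@@]2(C)C3(C)C)CC1` carries an ester link; in an ADME assay on HEK-293T cells (Homo sapiens) for cytotoxicity, read by MTT assay, with a stated time of 48 h (a lower number here means that less compound is tolerated, a higher number that more compound is tolerated), compound 1 gives 313000 nM. Compound 2 `CCN1CCN(CC(=O)O[C@@H]2C[C@@H]3CC[C@@]2(C)C3(C)C)CC1` differs from compound 1 by methyl in place of hydrogen on a saturated chain carbon bound to an amine nitrogen in a ring, and in this assay compound 2 gives 130000 nM, a step of a 2.4-fold lower number from compound 1 to compound 2 (0.38 log units; beyond the scatter). Compound 3 `CN1CCN(CC(=O)N[C@@H]2C[C@H]3CC[C@]2(C)C3(C)C)CC1` carries an amide link; how its core differs from that of compound 1 is not broken down here. In this assay compound 3 gives 853000 nM, the highest of the three numbers.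

Compound 4 `CCN1CCN(CC(=O)N[C@@H]2C[C@H]3CC[C@]2(C)C3(C)C)CC1` is not yet measured. It differs from compound 3 by methyl in place of hydrogen on a saturated chain carbon bound to an amine nitrogen in a ring, the same change that leads from compound 1 to compound 2. In this assay, for the measured compounds named here, the step from compound 3 to compound 4 is expected to be about a 2.4-fold lower number from compound 3 to compound 4 (0.37 log units; beyond the scatter), because the one earlier instance of this change gave a 2.4-fold lower number from compound 1 to compound 2 (0.38 log units; beyond the scatter), with the amide core as the only new element. Compound 4 is thus estimated at 360000 nM, with a range from 150000 nM to 850000 nM.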

Compound 4, half-maximal cytotoxic concentration: 660000 nM
The estimate for compound 4 lay 1.8-fold (0.26 log units) below the measured number; the measured number falls inside the stated range.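

On the amide core, methyl in place of hydrogen on a saturated chain carbon bound to an amine nitrogen in a ring gives, in this assay, a 1.3-fold lower number from compound 3 to compound 4 (0.11 log units; within the scatter), a step that cannot be told from the scatter. Set beside the step on the ester core, the two instances do not separate: the same change on two cores in this assay, a 2.4-fold lower number (0.38 log units; beyond the scatter) from compound 1 to compound 2 and a 1.3-fold lower number (0.11 log units; within the scatter) from compound 3 to compound 4, 1.9-fold (0.27 log units) apart, within the scatter of two such steps. They are compatible with one step size carried from core to core, but they do not show that the step is the same on both cores, and two pairs set no rule for the wider series.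

Left open is whether the same reading holds for a chain longer than ethyl on that ring amine nitrogen, such as propyl or butyl, or for such a chain ending in a hydroxyl or a carboxylic acid. Also open, going by these compounds, is how both cores would read in this assay with a free amine, hydrogen standing on that nitrogen in place of methyl or ethyl.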